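This account rests on a few compounds, and the source may have more. Where it says the series, first, only, none or still open, it means among the compounds named here.

Measured so far:
- compound 1 `COc1ccc(/C(=C\c2c[nH]c3ccc(OCc4ccccc4)cc23)C(=O)O)cc1`: 38500 nM
- compound 2 `COc1cc(/C(=C\c2cn(C(C)=O)c3ccc(OCc4ccccc4)cc23)C(=O)O)cc(OC)c1OC`: > 100000 nM
- compound 3 `COc1ccccc1/C(=C\c1cn(C(C)=O)c2ccc(OCc3ccccc3)cc12)C(=O)O`: > 100000 nM

In a functional assay on KB cells (Homo sapiens) for cytotoxicity, read by MTT assay, with a stated time of 72 h (a lower number here means a stronger inhibitor, a higher number a weaker inhibitor), compound 1 gives 38500 nM. Compound 2 reaches only a limit, > 100000 nM. Compound 3 also reaches only a limit, > 100000 nM. Compound 2 therefore stands at the top end of the numbers shown, and the step that the two limits leave unreadable from compound 2 to compound 3 cannot be sized because the limit of > 100000 nM in this assay, at which 2 of the 3 values shown sit, covers both ends.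

Compound 4 `COc1ccc(/C(=C\c2cn(C(C)=O)c3ccc(OCc4ccccc4)cc23)C(=O)O)cc1OC` differs from compound 2 by hydrogen in place of methoxy on an aromatic carbon. For the measured compounds named here, no measured step bears on this change with a readable size. With compound 2 at a limit, compound 4 is expected to stay close to it, with the step that the limit leaves unreadable from compound 2 to compound 4 expected not to exceed the scatter. Compound 4 is estimated at 110000 nM, range 35000 nM to 300000 nM.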

Compound 4, half-maximal inhibitory concentration: 96700 nM
Beside the measured number, compound 4's estimate is 1.1-fold (0.06 log units) above it; measured number inside the range.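

In this assay, hydrogen in place of methoxy on the 3,4,5-trimethoxyphenyl group gives an at least 1.0-fold lower number from compound 2 to compound 4 (0.01 log units; that floor lies within the scatter), so this position now carries a readable number where compound 2 holds only a limit. Set against the 2-methoxyphenyl group, the 3,4-dimethoxyphenyl group gives an at least 1.0-fold lower number from compound 3 to compound 4 (0.01 log units; that floor lies within the scatter). Neither step shows a change beyond the scatter, because each starts from a limit: the limit of > 100000 nM in this assay, at which 2 of the 4 values shown sit.

Still open, as far as these compounds go, is whether a hydroxyl or an amine at this position would bring the number clearly below that of compound 4. Whether any change at this position matters in this series remains equally unsettled.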